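This account rests on a few compounds, and the source may have more. Where it says the series, first, only, none or still open, it means among the compounds named here.

Working notes on the series.

Among the compounds with values here, compound 1, `O=C(COc1ccc(C(=O)/C=C/c2ccccc2Br)cc1)N[C@H]1CCOC1=O`, is the one member with a number in a functional assay on DU-145 cells (Homo sapiens) for antiproliferative activity, read by MTT assay, with a stated time of 72 h; a lower number here means a stronger inhibitor, a higher number a weaker inhibitor: in this assay compound 1 gives 3540 nM. Compound 2, `Cc1ccc(C(C)C)c(OCCSC(=S)N[C@H]2CCOC2=O)c1`, reaches only the limit of this assay, > 64000 nM. Compound 3, `O=C(CNc1ccc(Br)cc1)N[C@H]1CCOC1=O`, likewise reaches only the limit of this assay, > 64000 nM. Compound 1 therefore stands alone as the measured value, while the other two sit at the limit of > 64000 nM in this assay, at which 2 of the 3 values shown sit. Compound 2 and compound 3 share the lactone amine end of compound 1 but not the rest, so their limits say nothing about any single step from compound 1.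

Compound 4, `O=C(COc1ccc(C(=O)/C=C/c2ccc(Cl)cc2Cl)cc1)N[C@H]1CCOC1=O`, keeps the core of compound 1 and differs in one place: 2,4-dichlorophenyl in place of 2-bromophenyl on a double-bonded chain carbon bound to a double-bonded chain carbon. Within the data shown here, no measured step of this kind is available. The expectation for the step from compound 1 to compound 4 in this assay is a small one, no larger than the scatter, with, if anything, a slight lean toward a stronger inhibitor; the estimated step is a 1.4-fold lower number from compound 1 to compound 4 (0.13 log units; within the scatter). Compound 4 is thus expected to give about 2600 nM in this assay, with a range from 800 nM to 9000 nM.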

Compound 4, half-maximal inhibitory concentration: 8610 nM
The estimate for compound 4 lay 3.3-fold (0.52 log units) below the measured number, within the range that was stated.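

Within the data shown here, the aryl group on the double-bonded chain carbon bound to a double-bonded chain carbon now has a readable effect in this assay: 2,4-dichlorophenyl in place of 2-bromophenyl gives a 2.4-fold higher number from compound 1 to compound 4 (0.39 log units; beyond the scatter) and is the only step so far, so this position is not indifferent to the change. The step is modest, and compound 4 still gives a measured number rather than a limit, so with the core of compound 1 kept, this position accepts a phenyl carrying two chlorine atoms while a number remains readable. Nothing measured among the compounds shown accounts for the direction or size of this step.

The step exchanges bromine for chlorine and adds a second halogen in one move, so the compounds shown do not separate these two changes. Going by these compounds, whether a phenyl carrying a single chlorine, a methoxy group or an amine on the same chain carbon would stay close to compound 1 or move further from it remains open.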